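This account rests on a few compounds, and the source may have more. Where it says the series, first, only, none or still open, it means among the compounds named here.

Working notes on the series in a functional assay on HT-29 cells (Homo sapiens) for cytotoxicity, read by MTT assay, with a stated time of 72 h; a lower number here means a stronger inhibitor, a higher number a weaker inhibitor. Compound 1 `COc1cc2c(Oc3ccc(NC(=O)c4nn(-c5cccc(F)c5)c(=O)c5ccccc45)cc3F)ccnc2cc1OCCCN1CCCC1` gives 460 nM. Compound 2 `COc1cc2c(Oc3ccc(NC(=O)c4nn(-c5ccccc5)c(=O)c5ccccc45)cc3F)ccnc2cc1OCCCN1CCC(C)CC1` gives 1040 nM, and compound 3 `COc1cc2c(Oc3ccc(NC(=O)c4nn(-c5ccc(F)cc5)c(=O)c5ccccc45)cc3F)ccnc2cc1OCCCN1CCC(C)CC1` gives 330 nM. Compound 3 holds the lowest number of the three, but its gap to compound 1 lies within the scatter, while the step of a 3.2-fold lower number from compound 2 to compound 3 (0.50 log units; beyond the scatter) lies beyond it. Compound 4 `COc1cc2c(Oc3ccc(NC(=O)c4nn(-c5cccc(F)c5)c(=O)c5ccccc45)cc3F)ccnc2cc1OCCCN1CCC(C)CC1` has not yet been measured in this assay. It differs from compound 3 by 3-fluorophenyl in place of 4-fluorophenyl on an aromatic nitrogen. For the measured compounds named here, no measured step moves a fluorine between two positions on that ring: the one change seen at the same ring, a 3.2-fold lower number from compound 2 to compound 3 (0.50 log units; beyond the scatter), adds a fluorine rather than relocating one, and compound 1 carries the same 3-fluorophenyl as compound 4 but a different amine, so its value can only be set alongside without a step. The step is therefore expected to be a 1.4-fold higher number from compound 3 to compound 4 (0.13 log units; within the scatter), with no direction beyond the scatter. Compound 4 is expected to give about 450 nM, between 200 nM and 1000 nM.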

Compound 4, half-maximal inhibitory concentration: 500 nM
The estimate for compound 4 lay 1.1-fold (0.05 log units) below the measured number; the range from low to high includes it.
By their numbers in this assay, from the lowest: compounds 3, 1 and 4 (each within the scatter of the next); then compound 2.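

In this assay, a 1.5-fold higher number from compound 3 to compound 4 (0.18 log units; within the scatter) shows that 3-fluorophenyl in place of 4-fluorophenyl on the aromatic nitrogen is not separated from the earlier placement at this position. Adding the fluoro at this other ring position gives a 2.1-fold lower number from compound 2 to compound 4 (0.32 log units; beyond the scatter), so both fluoro placements now have a step from the unsubstituted phenyl beyond the scatter, alongside a 3.2-fold lower number from compound 2 to compound 3 (0.50 log units; beyond the scatter), though the step to compound 4 is only modest. With the 3-fluorophenyl held fixed, a 1.1-fold higher number from compound 1 to compound 4 (0.04 log units; within the scatter) shows that 4-methylpiperidin-1-yl in place of pyrrolidin-1-yl is also not separated here.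

The compounds shown leave open how a chloro or methoxy group on that phenyl ring, or a morpholine in place of the 4-methylpiperidin-1-yl, would read in this assay. Nothing available offers a measured reason for any of these steps.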